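The source may hold more compounds than are shown below. What is called first, only, known or untested is meant among the compounds shown, and "the series" means these compounds.

Measured compounds, with their results in a functional assay on DLD-1 cells (Homo sapiens) for cytotoxicity, read by WST assay, with a stated time of 72 h; on this read-out higher numbers stand for weaker inhibition and lower numbers for stronger inhibition:
Compound 1, `COc1cc2c(Nc3nc4ccc(C(=O)Nc5c(C)cccc5Cl)cc4s3)ncnc2cc1OCCCN1CCCCC1C`: 6700 nM
Compound 2, `COc1cc2c(Nc3nc4ccc(C(=O)Nc5c(C)cc(C)cc5C)cc4s3)ncnc2cc1OCCCN1CCCCC1C`: 5700 nM
Compound 3, `COc1cc2c(Nc3nc4ccc(C(=O)Nc5c(C)cccc5Cl)cc4s3)ncnc2cc1OCCCN1CCCCC1`: 14700 nM

Compound 4, `COc1cc2c(Nc3nc4ccc(C(=O)Nc5c(C)cc(C)cc5C)cc4s3)ncnc2cc1OCCCN1CCCCC1`, has not yet been measured in this assay. It differs from compound 3 by 2,4,6-trimethylphenyl in place of 2-chloro-6-methylphenyl on an amide-type nitrogen. The same change has already been made once, from compound 1 to compound 2: 2,4,6-trimethylphenyl in place of 2-chloro-6-methylphenyl on an amide-type nitrogen, and there it gave a 1.2-fold lower number from compound 1 to compound 2 (0.07 log units; within the scatter). The cores of the two pairs differ by hydrogen in place of methyl on a saturated ring carbon, a change that gave a 2.2-fold higher number from compound 1 to compound 3 (0.34 log units; beyond the scatter). The place of the change is the same in both pairs, so the same step is expected from compound 3 to compound 4, a 1.2-fold lower number from compound 3 to compound 4 (0.09 log units; within the scatter), resting on compound 1 to compound 2 a 1.2-fold lower number from compound 1 to compound 2 (0.07 log units; within the scatter). Compound 4 is therefore estimated at 12000 nM, expected between 6000 nM and 25000 nM.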

Compound 4, half-maximal inhibitory concentration: 24500 nM
Compound 4: middle estimate off by 2.0-fold (0.31 log units), on the low side; the range from low to high includes it.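

In this assay, putting 2,4,6-trimethylphenyl in place of 2-chloro-6-methylphenyl on the amide-type nitrogen gives a 1.7-fold higher number from compound 3 to compound 4 (0.22 log units; within the scatter), and this matches the same change on the other core: the same change on two cores in this assay, a 1.2-fold lower number (0.07 log units; within the scatter) from compound 1 to compound 2 and a 1.7-fold higher number (0.22 log units; within the scatter) from compound 3 to compound 4, 2.0-fold (0.29 log units) apart, within the scatter of two such steps. Putting hydrogen in place of methyl on a saturated ring carbon gives a 4.3-fold higher number from compound 2 to compound 4 (0.63 log units; beyond the scatter), and this also carries over: the same change on two cores in this assay, a 2.2-fold higher number (0.34 log units; beyond the scatter) from compound 1 to compound 3 and a 4.3-fold higher number (0.63 log units; beyond the scatter) from compound 2 to compound 4, 2.0-fold (0.29 log units) apart, within the scatter of two such steps. Each change therefore behaves alike on the two cores shown, within the scatter, but a single pair of steps per change cannot show that this holds on any other core.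

As far as these compounds go, it remains open whether a pyridyl group on the amide-type nitrogen would follow the same pattern. The same is true of an ethyl group in place of the methyl on the saturated ring carbon.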